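The source may hold more compounds than are shown below. What is called first, only, known or untested is meant among the compounds shown, and "the series" means these compounds.

Compound 3, with structure `Cc1cc(NC(=O)CN2CCC(c3cccc[n+]3[O-])CC2)ccc1F`, gives the lowest of the three numbers recorded in a functional assay on HEK293 cells for agonist activity at D(4) dopamine receptor (Homo sapiens), read by FLIPR; a higher number here means that more compound is needed for the effect, a lower number that less compound is needed: compound 3 gives 18 nM. Its nearest neighbour is compound 1, `Cc1cc(C(=O)NCN2CCC(c3cccc[n+]3[O-])CC2)ccc1F`, which in this assay gives 50 nM, and the furthest is compound 2, `O=C(CN1CCC(c2cccc[n+]2[O-])CC1)Nc1cccc(F)c1`, which gives 160 nM. Compound 4, `O=C(CN1CCC(c2cccc[n+]2[O-])CC1)Nc1cc(Cl)cc(Cl)c1`, has not yet been measured. It differs from compound 3 in one place: 3,5-dichlorophenyl in place of 4-fluoro-3-methylphenyl on an amide-type nitrogen.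

Among the measured compounds shown here, only one measured step touches the same position. The change of aryl group on the amide-type nitrogen gave an 8.9-fold lower number from compound 2 to compound 3 (0.95 log units; beyond the scatter), so a swap of ring substituents at this place has already moved the number by a modest amount. For the measured compounds named here, no measured pair exchanges a dichlorophenyl, so the direction of the present step cannot be read from the data; a step of comparable size in either direction would not surprise, and an expectation of a somewhat higher number is chosen as the middle case. The estimated step is a 2.2-fold higher number from compound 3 to compound 4 (0.35 log units; beyond the scatter). Compound 4 is therefore expected to give about 40 nM in this assay, with a range from 10 nM to 160 nM.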

Compound 4, half-maximal effective concentration: 160 nM
Compound 4: middle estimate off by 4.0-fold (0.60 log units), on the low side; the range from low to high includes it.
By their numbers in this assay, from the lowest: compound 3; then compound 1; then compounds 2 and 4 (each within the scatter of the next).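

In this assay, the step of an 8.9-fold higher number from compound 3 to compound 4 (0.95 log units; beyond the scatter) shows that a change of aryl group on the amide-type nitrogen can raise the number as well as lower it, and that a 3,5-dichlorophenyl group does not keep the low number of compound 3. The step of no change at the digits printed from compound 2 to compound 4 (within the scatter) adds that the 3,5-dichlorophenyl and 3-fluorophenyl groups cannot be told apart here, so of the three aryl groups at this place, only the 4-fluoro-3-methylphenyl group of compound 3 stands apart from the other two. No evidence is available that bears on this result.

The compounds shown leave open whether the low number of compound 3 goes with the methyl, the fluorine or the two together. A 3-methylphenyl or a 4-fluorophenyl group on the same nitrogen would bear on that question.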